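The source may hold more compounds than are shown below. What is called first, only, known or untested is meant among the compounds shown, and "the series" means these compounds.

Measured compounds:
- Compound 1, `C#CCOc1ccc(/C=C/C(=O)c2ccc(OC)cc2)cc1`, gives 25% in a functional assay on HepG2 cells (Homo sapiens) for inhibition, read by MTT assay, with a stated time of 48 h, tested at 10 uM; on this read-out higher numbers stand for more inhibition of growth at the one concentration tested and lower numbers for less inhibition of growth.
- Compound 2, `O=C(/C=C/c1ccc(OCc2cn(Cc3ccccc3Br)nn2)cc1)c1ccc(Br)cc1`, gives 34% in this assay.

Only these two compounds carry a number. In this assay, among the compounds with values here, compound 2 gives 34%, and in the same assay compound 1 gives 25%; the gap between them lies within the usual scatter of repeated measurements, so neither compound can be placed above the other, and no step between them is known. Compound 3, `O=C(/C=C/c1ccc(OCc2cn(Cc3ccc(F)cc3)nn2)cc1)c1ccc(Br)cc1`, has not yet been measured. It differs from compound 2 in one place: 4-fluorophenyl in place of 2-bromophenyl on a saturated chain carbon bound to an aromatic nitrogen. Within the data shown here, no measured pair shows what such a swap does on this read-out, so nothing in the data points to a direction. With no guidance from the measured compounds, the step from compound 2 to compound 3 is expected to be small, and is estimated as a number 2 percentage points lower from compound 2 to compound 3 (within the scatter), which would fall within the scatter. Compound 3 is therefore expected to give about 32% in this assay, with a likely range from 15% to 50%.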

Compound 3, percent growth inhibition at one concentration: 22%
For compound 3 the middle estimate is 10 percentage points above the measured one; the measured number falls inside the stated range.
By their numbers in this assay, from the lowest: compounds 3, 1 and 2 (each within the scatter of the next, the first and the last beyond it).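

Within the data shown here, the swap of 2-bromophenyl for 4-fluorophenyl gives a number 12 percentage points lower from compound 2 to compound 3 (beyond the scatter) in this assay and is the first step in this set that can be read at all. It shows that the group on this saturated chain carbon bound to an aromatic nitrogen can shift the growth inhibition beyond ordinary repeat-to-repeat variation, even though the incoming and outgoing groups have the same count of heavy atoms and the rest of the molecule stays unchanged, although the step is only modest in size. Nothing measured here says why the number moved.

This single step changes two things at once, the halogen and its place on the phenyl ring, so it cannot tell whether bromine itself, its place, or the two together account for the higher number of compound 2. A 4-bromophenyl or a 2-fluorophenyl group would pull these two changes apart, and a plain phenyl group would show what either halogen adds, while one pair alone cannot establish a trend for this position.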